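Bromo-dimethoxy hydrazones on the thiazole: measured and pending

The source may hold more compounds than are shown below. What is called first, only, known or untested is meant among the compounds shown, and "the series" means these compounds.

Measured so far:
Compound 1 `COc1cc(/C=N/Nc2nc(-c3ccccc3)cs2)c(Br)c(Br)c1OC`: in an ADME assay on HUVEC cells (Homo sapiens) for inhibition, read by MTT assay, with a stated time of 48 h (on this read-out lower numbers stand for stronger inhibition and higher numbers for weaker inhibition), compound 1 gives > 100000 nM, a limit of the assay and not a number.
Compound 2 `COc1ccccc1-c1csc(N/N=C/c2cc(OC)c(OC)c(Br)c2Br)n1`: in this assay compound 2 gives > 100000 nM, likewise a limit of the assay and not a number.

Compound 2 therefore stands at the limit (the limit of > 100000 nM in this assay, at which 2 of the 2 values shown sit), and so does compound 1; neither value is read as a number. Within the data shown here, the only step between measured compounds, a step that the two limits leave unreadable from compound 1 to compound 2, is the methoxy in place of hydrogen on an aromatic carbon, and the two limits leave its size unreadable.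

Compound 3 `COc1cc(/C=N/Nc2nc(-c3ccc(Br)cc3)cs2)c(Br)c(Br)c1OC` is not yet measured. It differs from compound 2 by 4-bromophenyl in place of 2-methoxyphenyl on an aromatic carbon, in words: 4-bromophenyl in place of 2-methoxyphenyl on an aromatic carbon. No measured step touches this position or this exchange, so the expectation for this assay rests only on where compound 2 stands, and since compound 2 sits at a limit, no direction of change can be read from the shown values. The step from compound 2 to compound 3 is therefore expected to be a step that the limit leaves unreadable from compound 2 to compound 3, which is no step beyond the scatter. Compound 3 is expected to give about 150000 nM in this assay, with a range from 40000 nM to 600000 nM, and most likely the assay will again report only a limit for compound 3.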

Compound 3, half-maximal inhibitory concentration: > 100000 nM
Compound 3 gave a limit, no number (the forecaster's own chance of this, stated with the estimate: 85%); the middle value does not contradict the limit.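

No new step can be read among compound 1, compound 2 and compound 3, whose results in this assay are all limits of the assay and not numbers: the limit of > 100000 nM in this assay, at which 3 of the 3 values shown sit. The compounds shown leave open whether any exchange on the shared core gives a readable number in this assay, and how large these steps are.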